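Carbapenem prodrug series: metabolic stability toward compound 3

This account rests on a few compounds, and the source may have more. Where it says the series, first, only, none or still open, it means among the compounds named here.

Measured so far:
compound 1 `CCOC(=O)OCOC(=O)C1=C(S[C@@H]2CN[C@H](C(=O)Nc3cccc(C(=O)OCOC(=O)OCC)c3)C2)[C@H](C)[C@@H]2[C@@H]([C@@H](C)O)C(=O)N12` — > 95%
compound 2 `CCOC(=O)OCOC(=O)C1=C(S[C@@H]2CN[C@H](C(=O)Nc3cccc(C(=O)O)c3)C2)[C@H](C)[C@@H]2[C@@H]([C@@H](C)O)C(=O)N12` — > 95%

In an ADME assay for metabolic stability, read by LC-MS, with a stated time of 3 h, at pH 6.5, tested at 50 uM (on this read-out lower numbers stand for a less stable compound and higher numbers for a more stable compound), the reading for compound 1, > 95%, is a limit of the assay and not a number. For compound 2 the reading > 95% in this assay is likewise a limit. The two compounds differ by hydrogen in place of ((ethoxycarbonyl)oxy)methyl on an oxygen next to a carbonyl group, and the step that the two limits leave unreadable from compound 1 to compound 2 cannot be sized, because both readings sit at the limit of > 95% in this assay, at which 2 of the 2 values shown sit. Going by the values given here, compound 2 therefore stands at the upper limit of this assay, alongside the only other value shown.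

Compound 3 `CC(C)C(=O)OCOC(=O)C1=C(S[C@@H]2CN[C@H](C(=O)Nc3cccc(C(=O)O)c3)C2)[C@H](C)[C@@H]2[C@@H]([C@@H](C)O)C(=O)N12` keeps the core of compound 2 and differs from it by isopropyl in place of ethoxy on a carbonyl carbon. Among the compounds with values here, no measured step touches this position; the single step in hand lies elsewhere and is itself unreadable. On the numbers shown, the expectation for the step from compound 2 to compound 3 in this assay is a number no higher from compound 2 to compound 3 (the limit leaves the size open), none beyond the scatter. Compound 3 is accordingly estimated at 95%, within 85% to 100%, most likely again reported as a limit.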

Compound 3, percent of the compound remaining: > 95%
Compound 3 was reported as a limit (the forecaster's own chance of this, stated with the estimate: 70%); the middle value sits exactly at the limit.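

No step can be read from compound 2 to compound 3 in this assay, because the readings of both are limits of the assay and not numbers: the limit of > 95% in this assay, at which 3 of the 3 values shown sit.

The compounds shown leave open whether isopropyl in place of ethoxy on a carbonyl carbon shifts the reading in this assay at all, and how compound 1, compound 2 and compound 3 rank there.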